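The source may report more compounds than this note shows. Statements on the series, on what has been measured and on what is new or still open speak of the compounds shown alone.

Measured so far in an assay for inhibition of MAP kinase-interacting serine/threonine-protein kinase 2 (Homo sapiens), read by TR-FRET; a higher number here means a weaker inhibitor, a lower number a stronger inhibitor:

compound 1 `CCn1cc(-c2ccnc(Nc3ccc(OC)cc3OC)n2)c2ccccc21`: 430 nM
compound 2 `Oc1ccccc1Nc1nccc(-c2c[nH]c3ccccc23)n1`: 120 nM
compound 3 `COc1ccc(Nc2nccc(-c3sc(SC(C)C)nc3C)n2)c(OC)c1`: 1300 nM

Compound 3 gives the highest of the three numbers. Its nearest neighbour is compound 1, lower by a margin beyond the scatter; compound 2 lies lower still, also beyond the scatter. Within the data shown here, no pair of measured compounds differs in a single place, so no counted step is available, and the three compounds share only the core and the amino-linked aryl group.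

Compound 4 `CNc1nc(C)c(-c2ccnc(Nc3ccc(OC)cc3OC)n2)s1` is not yet measured. It differs from compound 3 by methylamino in place of isopropylsulfanyl on an aromatic carbon. Neither compound 1 nor compound 2 carries a group of this kind, so they give no direct guide; the expectation rests on compound 3 alone, starting from 1300 nM. A step of moderate size toward a lower number is expected in this assay, a 2.2-fold lower number from compound 3 to compound 4 (0.34 log units; beyond the scatter), though a result within the scatter cannot be ruled out. Compound 4 is estimated at 600 nM, with a range from 200 nM to 1800 nM.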

Compound 4, inhibition constant: 110 nM
Compound 4: middle estimate off by 5.5-fold (0.74 log units), on the high side, and the stated range ends above it.
By their numbers in this assay, from the lowest: compounds 4 and 2 (each within the scatter of the next); then compound 1; then compound 3.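

In this assay, the position on the five-membered aromatic ring, next to the ring nitrogen and next to the ring sulfur, proves sensitive to its substituent: methylamino in place of isopropylsulfanyl gives a 12-fold lower number from compound 3 to compound 4 (1.07 log units; beyond the scatter), a large step and the first that can be read in this series. The entering group has fewer heavy atoms than the one it replaces, links through nitrogen rather than sulfur, and carries a hydrogen-bond donor that isopropylsulfanyl lacks. These differences arrive together in a single step, so this pair cannot assign the gain to any one of them.

Methylsulfanyl, dimethylamino or isopropylamino at this position would separate chain size, linking atom and the amine hydrogen. Nothing available here explains the size of this step.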